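This account rests on a few compounds, and the source may have more. Where it says the series, first, only, none or still open, it means among the compounds named here.

Measured compounds:
Compound 1 `Cc1ccccc1C(=O)n1c(-c2cn(-c3ccccc3)nc2-c2ccc(F)cc2)nc2ccccc21`: 189000 nM
Compound 2 `Cc1cccc(C(=O)n2c(-c3cn(-c4ccccc4)nc3-c3ccc(C(F)(F)F)cc3)nc3ccccc32)c1`: 154000 nM
Compound 3 `Cc1ccc(C(=O)n2c(-c3cn(-c4ccccc4)nc3-c3ccc(C(F)(F)F)cc3)nc3ccccc32)cc1`: 169000 nM

In an ADME assay on HEK-293T cells (Homo sapiens) for cytotoxicity, read by MTT assay, with a stated time of 24 h (a higher number here means that more compound is tolerated, a lower number that less compound is tolerated), compound 3 gives 169000 nM. It holds the second highest of the three numbers; its nearest neighbour is compound 2, and its furthest is compound 1, both within the scatter of it. Among the compounds with values here, the only single-point step among the measured compounds is a 1.1-fold higher number from compound 2 to compound 3 (0.04 log units; within the scatter), which also stays within the scatter.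

Compound 4 `Cc1ccccc1C(=O)n1c(-c2cn(-c3ccccc3)nc2-c2ccc(C(F)(F)F)cc2)nc2ccccc21` is not yet measured in this assay. It differs from compound 3 in one place: 2-methylphenyl in place of 4-methylphenyl on a carbonyl carbon. Within the data shown here, the same 2-methylphenyl on the carbonyl carbon is present in compound 1, whose number lies within the scatter of compound 3, although compound 1 carries a fluorine where compounds 3 and 4 carry a trifluoromethyl, so no step bears on the change directly. The methyl position has so far moved the number only within the scatter, so compound 4 is expected to show a 1.0-fold higher number from compound 3 to compound 4 (0.00 log units; within the scatter), a step no larger than the scatter in either direction. Compound 4 is therefore estimated at 170000 nM, with a range of 85000 nM to 340000 nM.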

Compound 4, half-maximal cytotoxic concentration: 179000 nM
Beside the measured number, compound 4's estimate is 1.1-fold (0.02 log units) below it; the measured number falls inside the stated range.
By their numbers in this assay, from the lowest: compounds 2, 3, 4 and 1 (each within the scatter of the next).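

In this assay, the three methylphenyl groups on the carbonyl carbon can now be compared with the trifluoromethyl held constant: 2-methylphenyl in place of 4-methylphenyl gives a 1.1-fold higher number from compound 3 to compound 4 (0.02 log units; within the scatter), and 2-methylphenyl in place of 3-methylphenyl gives a 1.2-fold higher number from compound 2 to compound 4 (0.07 log units; within the scatter), so neither swap moves the number beyond the scatter. Within the data shown here, with 2-methylphenyl held constant, the first direct reading of trifluoromethyl in place of fluoro on the aromatic carbon gives a 1.1-fold lower number from compound 1 to compound 4 (0.02 log units; within the scatter), which also leaves the number within the scatter. No measurement is available to explain this flat picture.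

Every compound shown carries a methylphenyl on the carbonyl carbon, so the effect of an amine or a carboxylic acid on that ring, or of a longer chain in place of the methyl, remains open. Among these compounds, the aromatic carbon is covered by only one pair, fluoro and trifluoromethyl, which leaves a nitrile or a methoxy group there unaddressed.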